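Extending the Chain on the Ring Nitrogen of Compound 1

The source may hold more compounds than are shown below. What is called first, only, known or untested is meant among the compounds shown, and "the series" means these compounds.

Going by the values given here, compound 1 `CCn1c(SC/C(=N/O)c2ccccc2)nnc1-c1cc(OC)c(OC)c(OC)c1` is the higher of the two compounds measured so far in a functional assay on the whole organism (strain albino) for inhibition, with Rattus norvegicus as the target, read by paw edema, with a stated time of 5 h, at a dose of 0.28 mmol/kg by the oral route (a higher number here means more inhibition at the dose given (going by the name of the read-out), a lower number less inhibition), where compound 1 gives 74%. Its nearest neighbour is compound 2 `CCn1c(SC/C(=N/O)c2ccccc2)nnc1-c1ccc(OC)c(OC)c1`, which in this assay gives 71%; the step of a number 3 percentage points lower from compound 1 to compound 2 (within the scatter) lies within the scatter, so the two cannot be ranked against each other.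

The next compound, compound 3 `C=CCn1c(SC/C(=N/O)c2ccccc2)nnc1-c1cc(OC)c(OC)c(OC)c1`, differs from compound 1 by vinyl in place of methyl on a saturated chain carbon bound to an aromatic nitrogen. Cut one bond further out, the same difference reads ethyl to allyl. Among the compounds with values here, no measured step touches this part of the shared core: the single step recorded so far, from compound 1 to compound 2, concerns a methoxy on the aromatic ring and stayed within the scatter. There is therefore nothing in the present numbers that points to a step beyond the scatter in either direction.

Compound 3 is accordingly expected to give about 72% in this assay, with a range from 58% to 85%, an estimated step of a number 2 percentage points lower from compound 1 to compound 3 (within the scatter) from compound 1.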

Compound 3, a percentage reported as inhibition, in the whole organism at one dose (the size of the read-out at that dose, not a potency): 77%
The estimate for compound 3 lay 5 percentage points below the measured number; measured number inside the range.
By their numbers in this assay, from the lowest: compounds 2, 1 and 3 (each within the scatter of the next).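

In this assay the change from ethyl to allyl gives a number 3 percentage points higher from compound 1 to compound 3 (within the scatter), the only step among the compounds shown that touches this part of the shared core. It shows that vinyl in place of methyl, on a saturated chain carbon bound to an aromatic nitrogen, leaves the inhibition at this dose indistinguishable from that of compound 1, so the two cannot be ranked, and the added double bond outside aromatic rings brings no change that can be told from the scatter. No independent measurement bears on this result, so it stands as a reading without an explanation.

The compounds shown leave open whether a larger change at this place, such as a longer chain like butyl, a benzyl group or a chain carrying an amine or a carboxylic acid, would produce a step beyond the scatter. They also leave open whether allyl in place of ethyl would read the same way on the core of compound 2, which carries one methoxy fewer on its aromatic ring.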